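Chloro on the Core of Compound 1: Expected Tolerance

This account rests on a few compounds, and the source may have more. Where it says the series, first, only, none or still open, it means among the compounds named here.

compound 1 `CC(=O)OC[C@H]1O[C@@H](CC(=O)/C=C2\C(=O)N(Cc3ccc(F)cc3)c3ccccc32)[C@H](OC(C)=O)[C@@H](OC(C)=O)[C@@H]1OC(C)=O` gives 119000 nM in an ADME assay on Vero cells (Chlorocebus sabaeus) for cytotoxicity, read by resazurin assay, with a stated time of 72 h; a lower number here means that less compound is tolerated, a higher number that more compound is tolerated
compound 2 `CC(=O)OC[C@H]1O[C@@H](CC(=O)/C=C2\C(=O)N(Cc3cccc(C)c3)c3ccccc32)[C@H](OC(C)=O)[C@@H](OC(C)=O)[C@@H]1OC(C)=O` gives 72500 nM in this assay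
compound 3 `CC(=O)OC[C@H]1O[C@@H](CC(=O)/C=C2\C(=O)Nc3ccccc32)[C@H](OC(C)=O)[C@@H](OC(C)=O)[C@@H]1OC(C)=O` gives 127000 nM in this assay

Among these three, compound 1 holds the second highest number in this assay; its nearest neighbour is compound 3, with a 1.1-fold higher number from compound 1 to compound 3 (0.03 log units; within the scatter), and its furthest is compound 2, with a 1.6-fold lower number from compound 1 to compound 2 (0.22 log units; within the scatter). Compound 4 `CC(=O)OC[C@H]1O[C@@H](CC(=O)/C=C2\C(=O)N(Cc3ccc(F)cc3)c3ccc(Cl)cc32)[C@H](OC(C)=O)[C@@H](OC(C)=O)[C@@H]1OC(C)=O` differs from compound 1 by chloro in place of hydrogen on an aromatic carbon, placed on a six-membered aromatic ring of carbon only within a fused system of two rings, meta and para to a fused ring. Going by the values given here, no measured step touches that ring; the steps seen, a 1.6-fold lower number from compound 1 to compound 2 (0.22 log units; within the scatter), a 1.1-fold higher number from compound 1 to compound 3 (0.03 log units; within the scatter) and a 1.8-fold higher number from compound 2 to compound 3 (0.24 log units; within the scatter), all alter the group on the amide-type nitrogen and all lie within the scatter. The expectation for compound 4 is therefore no step beyond the scatter, a 1.1-fold lower number from compound 1 to compound 4 (0.03 log units; within the scatter). Compound 4 is estimated at 110000 nM, between 55000 nM and 220000 nM.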

Compound 4, half-maximal cytotoxic concentration: 107000 nM
Compound 4: the middle estimate sits 1.0-fold (0.01 log units) above what was measured; the range from low to high includes it.
By their numbers in this assay, from the lowest: compounds 2, 4, 1 and 3 (each within the scatter of the next).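

Chloro in place of hydrogen, on the aromatic carbon meta and para to a fused ring, is the first change shown on the shared core rather than on the amide-type nitrogen, and in this assay it gives a 1.1-fold lower number from compound 1 to compound 4 (0.05 log units; within the scatter) as its step. Here too the step stays within the scatter, as the steps on the amide-type nitrogen did. No evidence on the cause of this result is available.

The compounds shown leave open whether an amine or a carboxylic acid at this position would also stay within the scatter. They also leave open whether chloro would do so with hydrogen on the amide-type nitrogen, as in compound 3.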